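Chloro in place of methyl on the aromatic ring

This account rests on a few compounds, and the source may have more. Where it says the series, first, only, none or still open, it means among the compounds named here.

Compound 1 `Cc1ccc(/C=C2\SC(=O)N(CCNC(=O)Nc3c(C)n(C)n(-c4ccccc4)c3=O)C2=O)cc1` gives 37400 nM
Compound 2 `Cc1ccc(/C=C2\SC(=O)N(CC(=O)Nc3c(C)n(C)n(-c4ccccc4)c3=O)C2=O)cc1` gives 65500 nM

For the measured compounds named here, only two compounds have been measured so far, both in a functional assay on MCF7 cells (Homo sapiens) for inhibition, read by MTT assay, with a stated time of 48 h; a lower number here means a stronger inhibitor, a higher number a weaker inhibitor. Compound 2 gives 65500 nM and compound 1 gives 37400 nM, and these two numbers lie within the usual scatter of repeated measurements. They are best read as one level of activity rather than as a ranking.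

The next compound, compound 3 `Cc1c(NC(=O)CN2C(=O)S/C(=C\c3ccc(Cl)cc3)C2=O)c(=O)n(-c2ccccc2)n1C`, has not yet been measured. It differs from compound 2 in one place (chloro in place of methyl on an aromatic carbon), with chloro in place of methyl on an aromatic carbon, so that 4-methylphenyl becomes 4-chlorophenyl.

Going by the values given here, both measured compounds carry the methyl, so no measured pair shows directly what this swap does. With no such evidence, the expectation in this assay is no step beyond the scatter, and compound 3 should stay near compound 2 at 65500 nM. The estimated 1.3-fold lower number from compound 2 to compound 3 (0.12 log units; within the scatter) is therefore expected to be small. For compound 3 the estimated value is 50000 nM, with an expected range from 20000 nM to 120000 nM.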

Compound 3, half-maximal inhibitory concentration: 42600 nM
Beside the measured number, compound 3's estimate is 1.2-fold (0.07 log units) above it; low and high end bracket the measured number.
By their numbers in this assay, from the lowest: compounds 1, 3 and 2 (each within the scatter of the next).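

For the compounds shown here, compound 2 and compound 3 form the first measured pair that isolates this swap, and a 1.5-fold lower number from compound 2 to compound 3 (0.19 log units; within the scatter) in this assay shows what replacing 4-methylphenyl with 4-chlorophenyl does at this position. That step lies within the scatter, so the two compounds are best read as one level of activity, and this place on the ring accepts chloro in place of methyl without a readable difference. No separate measurement is available to explain this outcome.

As far as these compounds go, the pair tests only a narrow exchange, one heavy atom for one heavy atom, with no hydrogen-bond donors or acceptors on either side, so it remains open whether an amine, a carboxylic acid or a longer alkyl chain at this same place would give a step beyond the scatter. Going by these compounds alone, also open is whether the swap from methyl to chloro would read the same way on the linker of compound 1, whose chain differs from the one shared by compound 2 and compound 3.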